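Bromophenyl gives way to methoxyphenyl on the chain carbon

The source may hold more compounds than are shown below. What is called first, only, known or untested is meant among the compounds shown, and "the series" means these compounds.

Compound 1 `Cc1ccc(CS(=O)(=O)/C(=C/c2ccc(N(C)C)cc2)C(=O)c2ccc(Cl)cc2)cc1` gives 50000 nM in a functional assay on DU-145 cells (Homo sapiens) for inhibition, read by trypan blue exclusion, with a stated time of 96 h; on this read-out higher numbers stand for weaker inhibition of growth and lower numbers for stronger inhibition of growth.
Compound 2 `Cc1ccc(CS(=O)(=O)/C(=C/c2cc(C)cc(C)c2)C(=O)c2ccc(Cl)cc2)cc1` gives 10000 nM in this assay.
Compound 3 `Cc1ccc(CS(=O)(=O)/C(=C/c2ccc(Br)cc2)C(=O)c2ccc(Cl)cc2)cc1` gives 25000 nM in this assay.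

Three compounds share one core and differ only in the ring held on a double-bonded chain carbon bound to a double-bonded chain carbon. Compound 3 has the second highest of the three numbers; its nearest neighbour is compound 1, which lies a 2.0-fold lower number from compound 1 to compound 3 (0.30 log units; within the scatter), and its furthest is compound 2, which lies a 2.5-fold higher number from compound 2 to compound 3 (0.40 log units; beyond the scatter).

Compound 4 `COc1ccccc1/C=C(\C(=O)c1ccc(Cl)cc1)S(=O)(=O)Cc1ccc(C)cc1` has not yet been measured in this assay. It differs from compound 3 as follows: 2-methoxyphenyl in place of 4-bromophenyl on a double-bonded chain carbon bound to a double-bonded chain carbon.

Every step measured so far touches this same ring. The largest, a 5.0-fold lower number from compound 1 to compound 2 (0.70 log units; beyond the scatter), is modest; the other two are smaller still. Exchanging one ring for another at this place has therefore never moved the number far. Compound 4 is expected to behave likewise, and its estimated step is a 1.2-fold higher number from compound 3 to compound 4 (0.08 log units; within the scatter), with no confident direction. Compound 4 is thus estimated at 30000 nM, expected to fall between 10000 nM and 90000 nM.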

Compound 4, concentration for 50% growth inhibition: 10000 nM
Beside the measured number, compound 4's estimate is 3.0-fold (0.48 log units) above it; the measured number falls inside the stated range.
By their numbers in this assay, from the lowest: compounds 2 and 4 (each within the scatter of the next); then compounds 3 and 1 (each within the scatter of the next).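

Compound 4 brings the first oxygen and the first hydrogen-bond acceptor into the entering ring at this place in this assay, yet it does not separate from the 3,5-dimethylphenyl ring, with no change at the digits printed from compound 2 to compound 4 (within the scatter). Its steps from the two rings named with a group at 4 are a 2.5-fold lower number from compound 3 to compound 4 (0.40 log units; beyond the scatter) and a 5.0-fold lower number from compound 1 to compound 4 (0.70 log units; beyond the scatter), so 2-methoxyphenyl and 3,5-dimethylphenyl now stand together at lower numbers than 4-bromophenyl and 4-(dimethylamino)phenyl, and no compound among these four goes against that split. Nothing measured here accounts for this split.

The compounds shown leave open whether the lower number of compound 4 goes with the methoxy group itself or with where it stands on the ring, a question that a 4-methoxyphenyl ring and a 2-bromophenyl ring would help to settle. They also leave open how a 2-hydroxyphenyl ring or a ring carrying a carboxylic acid would read at this place, and whether this split would hold on a core with another group in place of the 4-chlorophenyl ketone.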